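Aryl swaps on a triazole arm leave cytotoxicity unchanged

The source may hold more compounds than are shown below. What is called first, only, known or untested is meant among the compounds shown, and "the series" means these compounds.

Compound 1, `Cc1ccc(S(=O)(=O)Oc2ccc3c(c2C)[C@H](Cn2cc(-c4ccccc4)nn2)[C@@]24CC(=O)[C@@](C)(CC[C@@H]32)C4)cc1`, in a functional assay on HL-60 cells (Homo sapiens) for cytotoxicity, read by MTT assay, with a stated time of 4 days; on this read-out higher numbers stand for weaker inhibition and lower numbers for stronger inhibition: > 20000 nM, a limit of the assay.
Compound 2, `Cc1ccc(S(=O)(=O)Oc2ccc3c(c2C)[C@H](Cn2cc(-c4ccccn4)nn2)[C@@]24CC(=O)[C@@](C)(CC[C@@H]32)C4)cc1`, in this assay: > 20000 nM, also a limit.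
Compound 3, `Cc1ccc(S(=O)(=O)Oc2ccc3c(c2C)[C@H](Cn2cc(-c4ccc(Br)cc4)nn2)[C@@]24CC(=O)[C@@](C)(CC[C@@H]32)C4)cc1`, not yet measured.

Compound 2 therefore stands at the limit, where both measured values sit (the limit of > 20000 nM in this assay, at which 2 of the 2 values shown sit). The move to compound 3 replaces (4-bromophenyl in place of pyridin-2-yl on an aromatic carbon). Going by the values given here, the only measured step, a step that the two limits leave unreadable from compound 1 to compound 2, gives no readable size, so no direction beyond the scatter is expected. Compound 3 is expected to remain at the limit, near 30000 nM, between 10000 nM and 100000 nM. The estimated step that the limit leaves unreadable from compound 2 to compound 3 means essentially no change.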

Compound 3, half-maximal inhibitory concentration: > 20000 nM
Compound 3 ended at the assay's limit (the forecaster's own chance of this, stated with the estimate: 85%); the middle value is on the limit's open side.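

No step among compound 1, compound 2 and compound 3 can be read, as each value is a limit and not a number: the limit of > 20000 nM in this assay, at which 3 of the 3 values shown sit.

As far as these compounds go, whether these three aryl groups on the triazole arm differ at all in cytotoxicity remains open.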